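Ring to chain at the aryl terminus

A few compounds are considered here, and "the series" means these few. Any claim that something is new, unique, unknown or untested is made for them only; others in the source may bear on it.

Within this pair, compound 2 `COC(=O)/C=C/c1cccc(N(Cc2ccc(-c3c(OC)cccc3OC)cc2)C(=O)C2CCCCC2)c1` holds the lowest number: in an assay on isolated protein with Bile acid receptor (Homo sapiens) as the target (on this read-out lower numbers stand for an effect already at smaller amounts and higher numbers for an effect only at larger amounts of compound), compound 2 gives 77 nM, while compound 1 `COC(=O)/C=C/c1cccc(N(Cc2ccc(/C=C/c3scnc3C)cc2)C(=O)C2CCCCC2)c1` gives 227 nM. Among the compounds with values here, the only step measured so far, a 2.9-fold lower number from compound 1 to compound 2 (0.47 log units; beyond the scatter), brought in the aryl group that compound 3 `CCOC/C=C/c1ccc(CN(C(=O)C2CCCCC2)c2cccc(/C=C/C(=O)OC)c2)cc1` now gives up. Compound 3 differs from compound 2 by 3-ethoxyprop-1-en-1-yl in place of 2,6-dimethoxyphenyl on an aromatic carbon. Within the data shown here, because a 2.9-fold lower number from compound 1 to compound 2 (0.47 log units; beyond the scatter) was gained on installing the ring that now leaves, a move back toward the number of compound 1 is expected; the entering chain has no measured precedent, so the range is wide. For compound 3 the expected step is a 3.2-fold higher number from compound 2 to compound 3 (0.51 log units; beyond the scatter). Compound 3 is estimated at 250 nM, between 80 nM and 800 nM.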

Compound 3, half-maximal effective concentration: 198000 nM
Compound 3: the middle estimate sits 790-fold (2.90 log units) below what was measured, and the stated range ends below it.
By their numbers in this assay, from the lowest: compound 2; then compound 1; then compound 3.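

Putting 3-ethoxyprop-1-en-1-yl in place of 2,6-dimethoxyphenyl gives a 2600-fold higher number from compound 2 to compound 3 (3.41 log units; beyond the scatter) in this assay and shows that this position, on an aromatic carbon para to a large group, is far less forgiving than the first step suggested. With the double-bonded chain carbons kept, ethoxymethyl in place of 4-methyl-1,3-thiazol-5-yl gives an 870-fold higher number from compound 1 to compound 3 (2.94 log units; beyond the scatter) and so the double bond alone does not hold the number. No data here bear on the cause of this loss.

Open, from the compounds shown here alone, is whether a terminal ring is what counts, which a cyclohexyl or phenyl group at the end of the same chain would test. Also open, going by these compounds, is the role of the ether oxygen, which a plain pentenyl chain would address.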